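A few compounds are considered here, and "the series" means these few. Any claim that something is new, unique, unknown or untested is made for them only; others in the source may bear on it.

Compound 3 `O=C1c2ccccc2N(Cc2cccc(Cl)c2)S(=O)(=O)N1Cc1ccccc1` and compound 2 `O=C1c2ccccc2N(Cc2ccc(Cl)cc2)S(=O)(=O)N1Cc1ccccc1` share the same core and differ only in the chlorophenyl group on the saturated chain carbon bound to the sulfonamide nitrogen in the ring, while compound 1 `Cc1ccc(CN2c3ccccc3C(=O)N(Cc3ccccc3)S2(=O)=O)cc1` carries a methylphenyl group there instead. In a functional assay on MRC5 cells (Homo sapiens) (a higher number here means that more compound is tolerated, a lower number that less compound is tolerated), compound 1 gives 63000 nM; in this assay compound 2 gives 60000 nM and compound 3 gives 60000 nM. The three numbers sit close together: a 1.1-fold lower number from compound 1 to compound 2 (0.02 log units; within the scatter), a 1.1-fold lower number from compound 1 to compound 3 (0.02 log units; within the scatter) and no change at the digits printed from compound 2 to compound 3 (within the scatter), so compound 3 stands level with compound 2 and within the scatter of compound 1.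

Compound 4 `C#CCCN1c2ccccc2C(=O)N(Cc2ccccc2)S1(=O)=O` is the next compound, and its structural change from compound 3 is propargyl in place of 3-chlorophenyl on a saturated chain carbon bound to a sulfonamide nitrogen in a ring. For the measured compounds named here, none of the measured steps covers this kind of change: all three exchange one substituted phenyl group for another on that saturated chain carbon, and all three lie within the scatter. They show only that this position tolerates those aromatic variations without moving the readout, and they give no measured guidance for replacing the aromatic ring with a short chain carrying a triple bond. In the absence of a directly comparable step, the expectation is that compound 4 stays near the cluster of measured values, with no change at the digits printed from compound 3 to compound 4 (within the scatter) expected to be small. Compound 4 is therefore estimated at 60000 nM in this assay, with a range from 20000 nM to 150000 nM.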

Compound 4, half-maximal cytotoxic concentration: 77000 nM
The estimate for compound 4 lay 1.3-fold (0.11 log units) below the measured number; the range from low to high includes it.
By their numbers in this assay, from the lowest: compounds 2, 3, 1 and 4 (each within the scatter of the next).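

Replacing the aromatic group with propargyl on a saturated chain carbon bound to a sulfonamide nitrogen in a ring gives a 1.3-fold higher number from compound 3 to compound 4 (0.11 log units; within the scatter) and a 1.3-fold higher number from compound 2 to compound 4 (0.11 log units; within the scatter) and a 1.2-fold higher number from compound 1 to compound 4 (0.09 log units; within the scatter) in this assay. The earlier steps shown here only exchanged one substituted phenyl group for another, whereas these show that the number stays within the scatter even when the six-membered aromatic ring leaves and a triple bond outside aromatic rings enters, so at this position the read-out does not depend on an aromatic ring being present in these compounds. Nothing available here accounts for this flat result.

The compounds shown leave open whether an amine, a carboxylic acid or a longer chain at this place would also stay within the scatter, since the four groups compared carry no hydrogen-bond donors or acceptors and no net charge. For the compounds shown here, they also leave open what happens when the benzyl group shared by all four compounds gives way to another group, such as a methyl or a pyridylmethyl group, since every step so far concerns a single position on the shared core.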